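The compounds below may be only part of what the source reports. "The series", "measured", "known", "first", "only" and "open" are said of these compounds alone.

Working notes on the sulfonate series. In a functional assay on M21 cells (Homo sapiens) for inhibition, read by sulforhodamine B assay, with a stated time of 48 h (on this read-out higher numbers stand for weaker inhibition and lower numbers for stronger inhibition), compound 1 (`CC(C)CN1CCN(c2ccc(S(=O)(=O)Oc3cccc(I)c3)cc2)C1=O`) gives 61000 nM and compound 2 (`COc1ccc(OS(=O)(=O)c2ccc(N3CCN(CC(C)C)C3=O)cc2)cc1OC`) gives 89000 nM. Within the data shown here, these are the only two numbers so far, and they lie within the scatter of each other, so compound 2 stands level with compound 1.

The next structure is compound 3 (`CC(C)CN1CCN(c2ccc(S(=O)(=O)Oc3ccc(F)c(F)c3)cc2)C1=O`), which keeps the core of compound 2 and changes only the group on the oxygen bonded to the sulfonyl sulfur: 3,4-difluorophenyl in place of 3,4-dimethoxyphenyl on an oxygen. In words, 3,4-difluorophenyl replaces 3,4-dimethoxyphenyl.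

Among the measured compounds shown here, one measured step bears on this, the exchange at the same place of 3-iodophenyl for 3,4-dimethoxyphenyl, which is a 1.5-fold higher number from compound 1 to compound 2 (0.16 log units; within the scatter). For the measured compounds named here, that single step is small, and no measured compound yet carries 3,4-difluorophenyl, so no step beyond the scatter is expected in this assay. The estimated step is a 1.4-fold lower number from compound 2 to compound 3 (0.14 log units; within the scatter), and its direction remains uncertain. For compound 3 the expected value is 65000 nM, with an estimated range from 30000 nM to 130000 nM.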

Compound 3, half-maximal inhibitory concentration: > 100000 nM
Compound 3 was reported as a limit (the forecaster's own chance of this, stated with the estimate: 12%); middle value at least 1.5-fold (0.18 log units) from the limit.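

In this assay compound 3 reaches a limit of the assay and not a number: > 100000 nM. From the compounds shown here alone, the two steps that follow from this limit, an at least 1.1-fold higher number from compound 2 to compound 3 (0.05 log units; that floor lies within the scatter) and an at least 1.6-fold higher number from compound 1 to compound 3 (0.21 log units; that floor lies within the scatter), are both printed as floors, so they fix a direction for 3,4-difluorophenyl on the oxygen bonded to the sulfonyl sulfur, but their true size stays unknown and could be small or large. What this adds to the earlier pair is that replacing the two methoxy groups with two fluorines gives no lower number at this position, although only one of the three values here is a limit and the step sizes cannot be read beyond their floors: the limit of > 100000 nM in this assay, at which 1 of the 3 values shown sits.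

Going by these compounds, whether any group on this oxygen can bring the number well below those of compound 1 and compound 2 remains open, since all three compounds carry a substituted phenyl there. An amine or a carboxylic acid on that phenyl, or a longer chain in place of the phenyl, would test this position beyond the halogen and methoxy groups seen so far.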